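A few compounds are considered here, and "the series" means these few. Any claim that something is new, unique, unknown or untested is made for them only; others in the source may bear on it.

Three compounds built on one shared core were tested in a functional assay on HeLa cells (Homo sapiens) for antiproliferative activity, read by CCK-8 assay, with a stated time of 72 h; a higher number here means a weaker inhibitor, a lower number a stronger inhibitor. Compound 1 `O=C(Nc1cccc(-c2oc3cc(-c4ccc(F)cc4)ccc3c(=O)c2O)c1)c1ccc(F)cc1F` gives 10700 nM, compound 2 `O=C(Nc1cccc(-c2oc3cc(-c4ccc(F)cc4)ccc3c(=O)c2O)c1)c1ccc(Br)cc1` gives 9740 nM, and compound 3 `Cc1cccc(C(=O)Nc2cccc(-c3oc4cc(-c5ccc(F)cc5)ccc4c(=O)c3O)c2)c1` gives 6650 nM. Compound 3 carries the lowest of the three numbers, yet the steps leading to it, a 1.6-fold lower number from compound 1 to compound 3 (0.21 log units; within the scatter) and a 1.5-fold lower number from compound 2 to compound 3 (0.17 log units; within the scatter), both lie within the scatter, as does a 1.1-fold lower number from compound 1 to compound 2 (0.04 log units; within the scatter); the three compounds cannot be told apart in this assay.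

Compound 4 `O=C(Nc1cccc(-c2oc3cc(-c4ccc(F)cc4)ccc3c(=O)c2O)c1)c1cc(F)cc(F)c1` differs from compound 3 in one place: 3,5-difluorophenyl in place of 3-methylphenyl on a carbonyl carbon. Among the measured compounds shown here, the steps that bear on this change are the two in which the aryl group on the carbonyl carbon was exchanged, a 1.6-fold lower number from compound 1 to compound 3 (0.21 log units; within the scatter) from a difluorophenyl and a 1.5-fold lower number from compound 2 to compound 3 (0.17 log units; within the scatter) from a bromophenyl, neither of which went beyond the scatter. Compound 1 also carries a difluorophenyl on the carbonyl carbon and gave 10700 nM. On that basis the return to a difluorinated ring in compound 4 is expected to yield a number a little above that of compound 3, though not beyond the scatter, and the expected step is a 1.3-fold higher number from compound 3 to compound 4 (0.11 log units; within the scatter). Compound 4 is accordingly estimated at 8500 nM, with a likely range from 4500 nM to 17000 nM.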

Compound 4, half-maximal inhibitory concentration: 3380 nM
Estimate against measurement, compound 4: 2.5-fold (0.40 log units) above; measured number below the stated range.
By their numbers in this assay, from the lowest: compounds 4, 3, 2 and 1 (each within the scatter of the next, the first and the last beyond it).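

In this assay, the aryl group on the carbonyl carbon now gives its first steps beyond the scatter: a 3.2-fold lower number from compound 1 to compound 4 (0.50 log units; beyond the scatter) with 3,5-difluorophenyl in place of 2,4-difluorophenyl, and a 2.9-fold lower number from compound 2 to compound 4 (0.46 log units; beyond the scatter) with 3,5-difluorophenyl in place of 4-bromophenyl. The first of these exchanges keeps two fluorine atoms on the ring and alters only their arrangement, which shows that the presence of a difluorophenyl group does not by itself fix the number at this position, although both steps are modest and a 2.0-fold lower number from compound 3 to compound 4 (0.29 log units; within the scatter) with 3,5-difluorophenyl in place of 3-methylphenyl remains within the scatter. No measurement available here accounts for these differences.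

Going by these compounds, all four compounds vary only the aryl group on the carbonyl carbon, so it remains open whether a 3,5-dichlorophenyl or 3,5-dimethylphenyl group there would give a number in line with compound 4. On these data alone, it is also open how the number would respond to a nonaromatic group at this place, such as a chain carrying an amine or a carboxylic acid, or to a change elsewhere on the shared core.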